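Methoxy to propargyloxy on a shared core

This account rests on a few compounds, and the source may have more. Where it says the series, first, only, none or still open, it means among the compounds named here.

In a functional assay on HCT-116 cells (Homo sapiens) for inhibition, read by sulforhodamine B assay, with a stated time of 48 h, tested at 50 uM (on this read-out higher numbers stand for more inhibition of growth at the one concentration tested and lower numbers for less inhibition of growth), compound 1 (`COc1ccc([C@@H]2CC(=O)c3cc(CC=C(C)C)c(OC)cc3O2)cc1`) gives 68% and compound 2 (`COc1cc2c(cc1CC=C(C)C)/C(=N/NC(N)=O)C[C@@H](c1ccc(O)cc1)O2`) gives 87% in this read-out. Compound 1 stands lowest of the two measured numbers, and its gap to compound 2 lies beyond the scatter. Compound 3 (`C#CCOc1ccc([C@@H]2CC(=O)c3cc(CC=C(C)C)c(OC)cc3O2)cc1`) differs from compound 1 by ethynyl in place of hydrogen on a saturated chain carbon bound to an oxygen on an aromatic ring in one place, ethynyl in place of hydrogen on a saturated chain carbon bound to an oxygen on an aromatic ring, which reads as methoxy to propargyloxy. Among the compounds with values here, no measured pair shows this change. The estimated a number 3 percentage points lower from compound 1 to compound 3 (within the scatter) in this assay points slightly downward, and no step beyond the scatter is expected. For compound 3 the expected value is 65% within an estimated range from 48% to 80% in this assay for now.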

Compound 3, percent growth inhibition at one concentration: 75%
Compound 3: the middle estimate sits 10 percentage points below what was measured; low and high end bracket the measured number.
By their numbers in this assay, from the lowest: compounds 1 and 3 (each within the scatter of the next); then compound 2.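

In this assay, methoxy to propargyloxy gives a number 7 percentage points higher from compound 1 to compound 3 (within the scatter), the first step read at this place. On the shared core, ethynyl in place of hydrogen on a saturated chain carbon bound to an oxygen on an aromatic ring therefore leaves the number within the scatter, so this single change shows no measurable effect here. No measurement offered here bears on why this is so. From the compounds shown here alone, whether a longer chain, an amine or a carboxylic acid at this place would also stay within the scatter remains open.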